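The source may report more compounds than this note shows. Statements on the series, on what has been measured and on what is new or still open speak of the compounds shown alone.

Notes on the series.

Of the compounds shown here, two have been measured in a functional assay on HepG2 cells (Homo sapiens) for cytotoxicity, read by MTT assay, with a stated time of 48 h; a higher number here means a weaker inhibitor, a lower number a stronger inhibitor. Compound 1 `CC[N+](C)(CC)CC(=O)N1N=C(C)CC1c1ccccc1OC` gives 3670 nM in this assay. Compound 2 `O=C(c1ccccc1)N1N=C(c2cc3ccccc3oc2=O)CC1c1ccccc1` gives 36600 nM in this assay. Compound 2 therefore stands at the highest of the two numbers, and its gap to compound 1, the nearer of the two, lies beyond the scatter of repeated measurements. For the measured compounds named here, compound 1 and compound 2 differ in several places at once, so no single step between them can be read off; only their two values are known.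

Compound 3 `Cc1ccc(C(=O)N2N=C(c3cc4ccccc4oc3=O)CC2c2ccccc2)cc1` is not yet measured. It differs from compound 2 in one place: methyl in place of hydrogen on an aromatic carbon. Going by the values given here, no step of this kind between measured compounds is available, so the size of the expected effect rests on the change itself, which adds a single carbon without ring, donor, acceptor or charge. The step is expected to be small, a 1.2-fold lower number from compound 2 to compound 3 (0.09 log units; within the scatter), with no direction beyond the scatter claimed. For compound 3 the expected value in this assay is 30000 nM, within a range of 10000 nM to 90000 nM.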

Compound 3, half-maximal inhibitory concentration: 52300 nM
Beside the measured number, compound 3's estimate is 1.7-fold (0.24 log units) below it; measured number inside the range.
By their numbers in this assay, from the lowest: compound 1; then compounds 2 and 3 (each within the scatter of the next).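

Methyl in place of hydrogen on an aromatic carbon, para to a large group, gives a 1.4-fold higher number from compound 2 to compound 3 (0.16 log units; within the scatter) in this assay, the first step in the series that can be read in one place. Compound 2 and compound 3 therefore cannot be told apart in this assay: on the benzoyl group, phenyl and 4-methylphenyl sit within the scatter of each other, so this position accepts the added carbon without a separation between the two numbers, although one such step says little about the position in general. Nothing in hand bears on why the two numbers sit so close, and no cause can be offered for this step.

On these data alone, what remains open is whether a group other than methyl at this same place, such as a methoxy group, a chlorine atom, an amine or a carboxylic acid, would give a step beyond the scatter. Also open, as far as these compounds go, is whether the same methyl placed on the other phenyl ring of the shared core would read the same way, since one step at one place cannot answer that.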